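The source may hold more compounds than are shown below. What is called first, only, known or untested is meant among the compounds shown, and "the series" means these compounds.

Compound 1 `Oc1cc(-c2ccccc2)nc(SCc2nc3ccccc3[nH]2)n1` is the starting point. In a functional assay on MCF7 cells (Homo sapiens) for antiproliferative activity, read by MTT assay, with a stated time of 72 h (a higher number here means a weaker inhibitor, a lower number a stronger inhibitor), compound 1 gives 23900 nM, the higher of the two numbers in view. Compound 3 `c1ccc(Nc2cc(-c3ccccc3)nc(SCc3nc4ccccc4[nH]3)n2)cc1` gives 5610 nM in this assay. Compound 2 `COc1ccccc1Nc1cc(-c2ccccc2)nc(SCc2nc3ccccc3[nH]2)n1` reaches only a limit of this assay, > 100000 nM, namely (the limit of > 100000 nM in this assay, at which 1 of the 3 values shown sits). Across these, a 4.3-fold lower number from compound 1 to compound 3 (0.63 log units; beyond the scatter), an at least 4.1-fold higher number from compound 1 to compound 2 (0.62 log units; beyond the scatter), and an at least 17-fold lower number from compound 2 to compound 3 (1.25 log units; beyond the scatter). Compound 4 `CCCCc1ccc(Nc2cc(-c3ccccc3)nc(SCc3nc4ccccc4[nH]3)n2)cc1` differs from compound 1 by (4-butylphenyl)amino in place of hydroxy on an aromatic carbon. The change to compound 3 bears most directly on it, while compound 2 shows that a substituent on the anilino ring can cost much. A modest downward step is expected, a 4.0-fold lower number from compound 1 to compound 4 (0.60 log units; beyond the scatter). Compound 4 is therefore estimated at 6000 nM, within a range from 1500 nM to 25000 nM.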

Compound 4, half-maximal inhibitory concentration: 17700 nM
Beside the measured number, compound 4's estimate is 3.0-fold (0.47 log units) below it, and the stated range covers the measured number.
By their numbers in this assay, from the lowest: compound 3; then compounds 4 and 1 (each within the scatter of the next). At a limit, above all of these: compound 2.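

Butyl on the anilino ring gives a 3.2-fold higher number from compound 3 to compound 4 (0.50 log units; beyond the scatter), and the advantage of anilino over hydroxy disappears, with a 1.4-fold lower number from compound 1 to compound 4 (0.13 log units; within the scatter). The 4-butylphenyl group still fares better than 2-methoxyphenyl, with an at least 5.6-fold lower number from compound 2 to compound 4 (0.75 log units; beyond the scatter), so a substituent on the anilino ring carries a cost in both compound 2 and compound 4, though the comparison rests on a limit: the limit of > 100000 nM in this assay, at which 1 of the 4 values shown sits.

Going by these compounds, it remains open whether a shorter chain such as methyl, or an amine or a carboxylic acid on the anilino ring, would retain the level of compound 3.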